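A few compounds are considered here, and "the series" means these few. Any claim that something is new, unique, unknown or untested is made for them only; others in the source may bear on it.

Compound 1 `CC(=O)Oc1ccccc1C(=O)O[C@H]1CO[C@H]2[C@@H]1OC[C@H]2OC(=O)c1snnc1C` is the reference point of this step. For the measured compounds named here, in an ADME assay on a cell-free system (plasma, Homo sapiens) for metabolic stability, with Plasma (Rattus norvegicus) as the target, read by HPLC, at pH 7.4 (on this read-out lower numbers stand for a shorter-lived compound and higher numbers for a longer-lived compound), compound 1 gives 0.0642 h, the lowest of the two numbers measured so far; the nearest neighbour is compound 2 `CC(=O)Oc1ccccc1C(=O)O[C@H]1CO[C@H]2[C@@H]1OC[C@H]2OC(=O)c1ccc(C)cc1`, which in this assay gives 0.105 h. Going by the values given here, the one measured step that exchanges the group on the carbonyl carbon is a 1.6-fold higher number from compound 1 to compound 2 (0.21 log units; within the scatter), so those two values are not separated beyond the usual scatter.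

Compound 3 `CC(=O)Oc1ccccc1C(=O)O[C@H]1CO[C@H]2[C@@H]1OC[C@H]2OC(=O)c1ccc(-c2ccccc2)cc1` is still to be measured in this assay. It differs from compound 1 in one place: 4-phenylphenyl in place of 4-methyl-1,2,3-thiadiazol-5-yl on a carbonyl carbon. Among the compounds with values here, the exchange is of the same kind as the measured step, an aromatic ring of carbon only replacing the 4-methyl-1,2,3-thiadiazol-5-yl group on the carbonyl carbon, but no measured step covers the 4-phenylphenyl group itself, so its effect is read across from the single step available. The step expected for compound 3 in this assay is a 1.9-fold higher number from compound 1 to compound 3 (0.27 log units; within the scatter), a modest shift upward that need not be clearly beyond the scatter. Compound 3 is accordingly estimated at 0.12 h, with a range from 0.05 h to 0.3 h.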

Compound 3, half-life: > 0.333 h
Compound 3 was reported as a limit (the forecaster's own chance of this, stated with the estimate: 5%); middle value at least 2.7-fold (0.44 log units) from the limit.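

In this assay compound 3 is reported only as a limit of the assay, not as a number: the limit of > 0.333 h in this assay, at which 1 of the 3 values shown sits. Even so, the group on the carbonyl carbon now separates the compounds, which the exchange between compound 1 and compound 2 did not do: the change to 4-phenylphenyl gives an at least 5.1-fold higher number from compound 1 to compound 3 (0.71 log units; beyond the scatter). The smaller change, phenyl in place of methyl on an aromatic carbon, also clears the scatter, with an at least 3.1-fold higher number from compound 2 to compound 3 (0.50 log units; beyond the scatter), so in these three compounds the separation appears only with 4-phenylphenyl on the carbonyl carbon, while the two single-ring groups stay within the scatter of each other.

From the compounds shown here alone, with only a limit for compound 3, the full size of both steps stays open, and so does how far the read-out would go on this position. Also open, going by these compounds, is whether the second phenyl ring itself is needed, or whether a butyl chain, a methoxy group, an amine or a pyridyl ring on the same aromatic carbon would give a step of similar size.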